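Second methoxy on the shared core: an expectation

The source may hold more compounds than are shown below. What is called first, only, known or untested is meant among the compounds shown, and "the series" means these compounds.

Measured so far:
compound 1 `COc1ccc(-c2nc(SCC(=O)c3sc(-c4ccccc4)nc3C)nc(N)c2C#N)cc1` — 27200 nM
compound 2 `Cc1nc(-c2ccccc2)sc1C(=O)CSc1nc(N)c(C#N)c(-c2ccccc2)n1` — 30100 nM

In a functional assay on MCF7 cells (Homo sapiens) for antiproliferative activity, read by MTT assay, with a stated time of 48 h (on this read-out higher numbers stand for weaker inhibition and lower numbers for stronger inhibition), compound 1 gives the lowest of the two numbers, yet its nearest neighbour sits within the scatter: the step of a 1.1-fold higher number from compound 1 to compound 2 (0.04 log units; within the scatter) came with hydrogen in place of methoxy on an aromatic carbon, and it shows that removing one methoxy from the shared core hardly moved the read-out. Compound 3 `COc1ccc(-c2nc(C)c(C(=O)CSc3nc(N)c(C#N)c(-c4ccc(OC)cc4)n3)s2)cc1` is not yet measured. It differs from compound 1 by methoxy in place of hydrogen on an aromatic carbon, on an aromatic carbon of a six-membered aromatic ring of carbon only, para to a large group. Within the data shown here, the one relevant measured step, a 1.1-fold higher number from compound 1 to compound 2 (0.04 log units; within the scatter), was within the scatter, so a second methoxy is expected to change this assay by no more than the scatter, in no fixed direction. Compound 3 is therefore estimated at 25000 nM (range 12000 nM to 55000 nM), the step of a 1.1-fold lower number from compound 1 to compound 3 (0.04 log units; within the scatter) being expected to stay small.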

Compound 3, half-maximal inhibitory concentration: 24300 nM
For compound 3 the middle estimate is 1.0-fold (0.01 log units) above the measured one; the measured number falls inside the stated range.
By their numbers in this assay, from the lowest: compounds 3, 1 and 2 (each within the scatter of the next).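

In this assay, the change from phenyl to 4-methoxyphenyl, on an aromatic carbon of a six-membered aromatic ring of carbon only and para to a large group, gave a 1.1-fold lower number from compound 1 to compound 3 (0.05 log units; within the scatter). The earlier step concerned the methoxy on the other aromatic ring, so this result extends the picture to a second place on the shared core: adding a methoxy here also left the read-out within the scatter. Compound 3 thus carries a methoxy on both rings, with a value that cannot be told apart from that of compound 1. No independent evidence bears on this result.

The compounds shown leave open whether an amine, a carboxylic acid or a longer chain such as butoxy at this place would move the read-out beyond the scatter. They also leave open whether any replacement of the methoxy at this place would do so.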